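A few compounds are considered here, and "the series" means these few. Any claim that something is new, unique, unknown or untested is made for them only; others in the source may bear on it.

Measured compounds and their values in an ADME assay on HEK293 cells (Homo sapiens) for cytotoxicity, read by reporter gene assay and resazurin assay, with a stated time of 48 h; a lower number here means that less compound is tolerated, a higher number that more compound is tolerated:

compound 1, `O=C(Nc1ccc(Sc2nc3ccccc3s2)cc1)c1cc(Br)cc(Br)c1O` — 66000 nM
compound 2, `O=C(Nc1ccccc1)c1cccc(Br)c1O` — 82000 nM
compound 3, `O=C(Nc1ccccc1)c1cc(Br)ccc1O` — 35000 nM

Compound 1 stands second highest of the three numbers in this assay, yet neither neighbour separates from it: compound 2 with 82000 nM sits within the usual scatter of compound 1, and compound 3 with 35000 nM does likewise. The three values therefore cannot be put in order, and compound 1 is to be read as tolerated about as well as the other two. For the measured compounds named here, no pair of measured compounds differs in only one place, so no measured step exists to lean on.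

Compound 4, `O=C(Nc1ccc(Sc2nc3ccccc3s2)cc1)c1cc(Br)cc(Br)c1`, is the next compound for this assay. It differs from compound 1 in one place: hydrogen in place of hydroxy on an aromatic carbon. Going by the values given here, nothing among the measured compounds bears directly on this change; the series so far carries a hydroxy on the benzamide ring throughout.

Among the compounds with values here, with no guiding step, the expected step of no change at the digits printed from compound 1 to compound 4 (within the scatter) from compound 1 is none beyond the scatter, in either direction. Compound 4 is accordingly estimated at 66000 nM in this assay, with a range from 30000 nM to 140000 nM.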

Compound 4, half-maximal cytotoxic concentration: > 100000 nM
Compound 4 was reported as a limit; the forecaster's own chance of this, stated with the estimate: 10%; at least 1.5-fold (0.18 log units) between middle value and limit.
By their numbers in this assay, from the lowest: compounds 3, 1 and 2 (each within the scatter of the next, the first and the last beyond it). At a limit, above all of these: compound 4.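

In this assay compound 4 gives > 100000 nM, which is a limit of the assay and not a number. Hydrogen in place of hydroxy at this aromatic carbon, ortho to a bromo group and para to a bromo group, gives an at least 1.5-fold higher number from compound 1 to compound 4 (0.18 log units; that floor lies within the scatter); the change from 3,5-dibromo-2-hydroxyphenyl to 3,5-dibromophenyl therefore shows no sign of lowering the tolerated concentration, though with that floor a real rise is not established either. The earlier compounds all carry the hydroxy, so this is the first view of the series without it, and the size of the step is bounded on one side only: the limit of > 100000 nM in this assay, at which 1 of the 4 values shown sits.

Going by these compounds, how far the value of compound 4 lies past its limit stays open, as does whether the same loss of hydroxy would read alike on a core without the second bromo group or the large group of compound 1. On these data alone, whether a methoxy or an amine on this aromatic carbon would read like the hydroxy or like hydrogen also remains open.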